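Acetoxy to Hydroxy on Two Different Cores

This account rests on a few compounds, and the source may have more. Where it says the series, first, only, none or still open, it means among the compounds named here.

Measured so far in an ADME assay on DU-145 cells (Homo sapiens) for cytotoxicity, read by MTT assay, with a stated time of 72 h; a lower number here means a stronger inhibitor, a higher number a weaker inhibitor:
- compound 1, `COc1ccc(C2=C(c3cc(OC)c(OC)c(OC)c3)C(=O)C(OC(C)=O)C2)cc1OC(C)C`: compound 1 gives only the limit > 100 ug/mL
- compound 2, `CC(=O)OC1C/C(=N/O)C(c2ccccc2)=C1c1ccccc1`: compound 2 gives only the limit > 100 ug/mL
- compound 3, `COc1ccc(C2=C(c3cc(OC)c(OC)c(OC)c3)C(=O)C(O)C2)cc1OC(C)C`: compound 3 gives only the limit > 100 ug/mL

Compound 3 arises from compound 1 by hydrogen in place of acetyl on an oxygen on a saturated carbon. Since both values are limits, the step that the two limits leave unreadable from compound 1 to compound 3 has no readable size; this is the situation that the limit of > 100 ug/mL in this assay, at which 3 of the 3 values shown sit, describes. The same change, (hydrogen in place of acetyl on an oxygen on a saturated carbon), leads from compound 2 to the not yet measured compound 4, `O/N=C1/CC(O)C(c2ccccc2)=C1c1ccccc1`. The difference between the cores of compound 1 and compound 2 is not broken down here.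

In this assay, among the measured compounds shown here, the step that the limit leaves unreadable from compound 2 to compound 4 is expected to be small, because every value so far sits where the limit of > 100 ug/mL in this assay, at which 3 of the 3 values shown sit, places it and the one measured instance of this change did not move a compound off that limit. Compound 4 is accordingly estimated at 150 ug/mL, most likely between 50 ug/mL and 500 ug/mL, and very probably reported only as a limit again.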

Compound 4, half-maximal inhibitory concentration: > 100 ug/mL
Compound 4 was reported as a limit (the forecaster's own chance of this, stated with the estimate: 85%); the middle value does not contradict the limit.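

Compound 2 and compound 4 both stand only as limits, so no step between them can be read: the limit of > 100 ug/mL in this assay, at which 4 of the 4 values shown sit.

The compounds shown leave open what acetoxy to hydroxy does to a compound with a value inside the readable range.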